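Moving the amide aryl substituent: from compound 3 to compound 4

This account rests on a few compounds, and the source may have more. Where it says the series, first, only, none or still open, it means among the compounds named here.

Measured compounds:
- compound 1, `Cc1ccc(C(=O)Nc2cccc(-c3oc4cc(-c5ccc(F)cc5)ccc4c(=O)c3O)c2)cc1`, 2400 nM
- compound 2, `O=C(Nc1cccc(-c2oc3cc(-c4ccc(F)cc4)ccc3c(=O)c2O)c1)c1ccc(Cl)cc1`, 4730 nM
- compound 3, `Cc1cccc(C(=O)Nc2cccc(-c3oc4cc(-c5ccc(F)cc5)ccc4c(=O)c3O)c2)c1`, 7850 nM

All three share one core and differ only in the aryl group attached to the amide carbonyl. In a functional assay on MCF7 cells (Homo sapiens) for antiproliferative activity, read by CCK-8 assay, with a stated time of 72 h (on this read-out lower numbers stand for stronger inhibition and higher numbers for weaker inhibition), compound 3 gives the highest of the three numbers: the step of a 3.3-fold higher number from compound 1 to compound 3 (0.51 log units; beyond the scatter) is beyond the scatter, while the step of a 1.7-fold higher number from compound 2 to compound 3 (0.22 log units; within the scatter) is not.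

Compound 4, `COc1ccc(C(=O)Nc2cccc(-c3oc4cc(-c5ccc(F)cc5)ccc4c(=O)c3O)c2)c(F)c1`, has not yet been measured. Compared with compound 3 the change is 2-fluoro-4-methoxyphenyl in place of 3-methylphenyl on a carbonyl carbon. The measured steps that bear on this are those between aryl groups on the same carbonyl: a 3.3-fold higher number from compound 1 to compound 3 (0.51 log units; beyond the scatter) and a 2.0-fold higher number from compound 1 to compound 2 (0.29 log units; within the scatter). Both carriers of a 4-substituted aryl, compound 1 and compound 2, gave lower numbers than compound 3, and swapping one 4-substituent for another stayed within the scatter. Compound 4 again carries a substituent in the 4-position, with an additional fluorine, so a moderately lower number than compound 3 is expected, roughly a 2.2-fold lower number from compound 3 to compound 4 (0.35 log units; beyond the scatter) in this assay. For compound 4 the expected value is 3500 nM, estimated to lie between 1200 nM and 10000 nM.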

Compound 4, half-maximal inhibitory concentration: 20000 nM
Compound 4: middle estimate off by 5.7-fold (0.76 log units), on the low side; the measured number lies above the stated range.
By their numbers in this assay, from the lowest: compounds 1, 2 and 3 (each within the scatter of the next, the first and the last beyond it); then compound 4.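

In this assay, within the data shown here, the new aryl group gives a 2.5-fold higher number from compound 3 to compound 4 (0.41 log units; beyond the scatter), a 4.2-fold higher number from compound 2 to compound 4 (0.63 log units; beyond the scatter) and an 8.3-fold higher number from compound 1 to compound 4 (0.92 log units; beyond the scatter), so changing this group can raise the number well beyond what the earlier compounds showed. A substituent in the 4-position therefore does not by itself keep the number low: 4-methylphenyl and 4-chlorophenyl fit that reading, but 2-fluoro-4-methoxyphenyl goes against it and even stands above 3-methylphenyl. Nothing available here accounts for this rise.

The compounds shown leave open whether the fluoro group, the methoxy group or the two together go with the higher number. Also open, going by these compounds, is how an amine or a carboxylic acid on this aromatic ring, or a longer chain in its place, would read in this assay.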